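The source may hold more compounds than are shown below. What is called first, only, known or untested is meant among the compounds shown, and "the series" means these compounds.

Compound 1 `Cc1nc(N2CCC(N3CCOC3=O)CC2)nc2ccc(NC(=O)/C=C/c3ccc(OC(F)(F)F)cc3)cc12` — 85% in an ADME assay on microsomes from liver (Homo sapiens) for metabolic stability, with a stated time of 30 min; a higher number here means that more of the compound is left, a lower number that less of the compound is left.
Compound 2 `C/C(=C\C(=O)Nc1ccc2nc(N3CCC(N4CCCC4=O)CC3)nc(C)c2c1)c1ccc(OC(F)(F)F)cc1` — "not determined" (no result reported).

Two compounds were made, but only one of them carries a number. In this assay, within the data shown here, compound 1 gives 85%, and as the only value in hand it is both the starting point and the whole of what is known; compound 2 returned "not determined" (no result reported), so nothing can be said about how the two compare.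

Compound 3 `Cc1nc(N2CCC(N3CCNC3=O)CC2)nc2ccc(NC(=O)/C=C/c3ccc(OC(F)(F)F)cc3)cc12` differs from compound 1 in one spot: 2-oxoimidazolidin-1-yl in place of 2-oxo-1,3-oxazolidin-3-yl on a saturated ring carbon. Among the measured compounds shown here, the change is small, swaps one five-membered ring for another of the same size and carries no step between measured compounds to lean on.

Given how little is known, no shift beyond the usual scatter is expected from compound 1 to compound 3, so the expected step of a number 5 percentage points lower from compound 1 to compound 3 (within the scatter) is essentially flat. For compound 3 the estimated value in this assay is 80%, with a likely range from 60% to 95%.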

Compound 3, percent of the compound remaining: 83%
For compound 3 the middle estimate is 3 percentage points below the measured one, within the range that was stated.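

Among these compounds, compound 1 and compound 3 form the first pair here that can be compared directly. In this assay, placing 2-oxoimidazolidin-1-yl on the saturated ring carbon instead of 2-oxo-1,3-oxazolidin-3-yl gives a number 2 percentage points lower from compound 1 to compound 3 (within the scatter), so the two compounds cannot be told apart in this read-out, even though the entering group carries a hydrogen-bond donor and the leaving group has none. Nothing at hand measures what either ring does in the compounds, so the result can be recorded but not explained.

The compounds shown leave open whether this position accepts only close relatives of these two five-membered rings, or whether a plain amine, a carboxylic acid or a longer alkyl chain on the same ring carbon would give a similar reading. They also leave open whether the result would hold for other parts of the molecule, since this one pair speaks only for this single exchange on the core of compound 1.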